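Aryl swap from compound 3 to compound 4

The source may report more compounds than this note shows. Statements on the series, on what has been measured and on what is new or still open speak of the compounds shown alone.

Measured in an ADME assay on L132 cells (Homo sapiens) for cytotoxicity, read by MTT assay, with a stated time of 48 h; on this read-out higher numbers stand for weaker inhibition and lower numbers for stronger inhibition:
- Compound 1 `C/C(=C\CC/C(C)=C/CC[C@@H]1[C@@]2(C)CCC(=O)C(C)(C)[C@H]2CC[C@@]1(C)O)CC/C=C(\C)C(=O)OCc1cn(-c2ccccc2C(F)(F)F)nn1`: > 150000 nM
- Compound 2 `C/C(=C\CC/C(C)=C/CC[C@@H]1[C@@]2(C)CCC(=O)C(C)(C)[C@H]2CC[C@@]1(C)O)CC/C=C(\C)C(=O)OCc1cn(-c2cccc(C)c2)nn1`: > 150000 nM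
- Compound 3 `C/C(=C\CC/C(C)=C/CC[C@@H]1[C@@]2(C)CCC(=O)C(C)(C)[C@H]2CC[C@@]1(C)O)CC/C=C(\C)C(=O)OCc1cn(-c2ccc(Br)cc2)nn1`: > 150000 nM

Each entry is a limit of the assay and not a number. Compound 3 stands at > 150000 nM, which is a limit and gives it no numeric rank. Going by the values given here, the series so far reads as the limit of > 150000 nM in this assay, at which 3 of the 3 values shown sit.

Compound 4 `C/C(=C\CC/C(C)=C/CC[C@@H]1[C@@]2(C)CCC(=O)C(C)(C)[C@H]2CC[C@@]1(C)O)CC/C=C(\C)C(=O)OCc1cn(-c2cccc(O)c2)nn1` carries 3-hydroxyphenyl in place of 4-bromophenyl on an aromatic nitrogen.

Three measured aryl swaps bear on this change: a step that the two limits leave unreadable from compound 1 to compound 2, a step that the two limits leave unreadable from compound 1 to compound 3 and a step that the two limits leave unreadable from compound 2 to compound 3. None of them has a readable size, so they offer no direction for a shift in this assay. No step beyond the scatter is expected, and another reading at the limit is the likeliest outcome.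

The expected change is a step that the limit leaves unreadable from compound 3 to compound 4.

The estimate for compound 4 is 200000 nM, with an expected range of 100000 nM to 400000 nM.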

Compound 4, half-maximal inhibitory concentration: 146000 nM
Estimate against measurement, compound 4: 1.4-fold (0.14 log units) above; the range from low to high includes it.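

In this assay compound 4, with 3-hydroxyphenyl on the aromatic nitrogen, gives 146000 nM, the only numeric reading among the compounds shown. The aryl swap gives an at least 1.0-fold lower number from compound 3 to compound 4 (0.01 log units; that floor lies within the scatter), hydroxy in place of methyl gives an at least 1.0-fold lower number from compound 2 to compound 4 (0.01 log units; that floor lies within the scatter), and the swap from 2-(trifluoromethyl)phenyl gives an at least 1.0-fold lower number from compound 1 to compound 4 (0.01 log units; that floor lies within the scatter), so adding a hydrogen-bond donor at this position produces no step shown to exceed the scatter. The aryl position still shows no readable trend: the limit of > 150000 nM in this assay, at which 3 of the 4 values shown sit.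

On these data alone, whether an aminophenyl or carboxyphenyl group on this nitrogen would give a clearly lower number remains open. Also open, as far as these compounds go, is whether 4-hydroxyphenyl would read like 3-hydroxyphenyl.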